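The compounds below may be only part of what the source reports. "The series", "measured", "known", "first", "only" and "open" are said of these compounds alone.

Compound 1 `Cc1nn2c(-c3nc4cc(Cl)c(F)cc4[nH]3)c(-c3ccc(F)cc3)nc2s1`: > 30000 nM
Compound 2 `Cc1nn2c(-c3nc4cc(Cl)ccc4[nH]3)c(-c3ccc(F)cc3)nc2s1`: 14400 nM
Compound 3 `Cc1nn2c(-c3nc4cc(Cl)c(Cl)cc4[nH]3)c(-c3ccc(F)cc3)nc2s1`: > 30000 nM

These results come from a functional assay on DU-145 cells (Homo sapiens) for antiproliferative activity, read by MTT assay; a lower number here means a stronger inhibitor, a higher number a weaker inhibitor. Compound 1 stands at > 30000 nM, which is a limit and not a number. Among the compounds with values here, the series so far shows (the limit of > 30000 nM in this assay, at which 2 of the 3 values shown sit). Only compound 2 gives a true number.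

Compound 4 `Cc1ccc(-c2nc3sc(C)nn3c2-c2nc3cc(Cl)c(F)cc3[nH]2)cc1` keeps the core of compound 1 and changes one group, 4-fluorophenyl to 4-methylphenyl: methyl in place of fluoro on an aromatic carbon.

Within the data shown here, no measured step touches this group, since all three tested compounds carry the same 4-fluorophenyl. The nearest evidence comes from changes on another part of the molecule. There we see an at least 2.0-fold lower number from compound 1 to compound 2 (0.31 log units; beyond the scatter) and an at least 2.0-fold higher number from compound 2 to compound 3 (0.31 log units; beyond the scatter), both modest at the least, while a step that the two limits leave unreadable from compound 1 to compound 3. These steps offer only a loose guide, so no clear change in either direction is expected, and compound 4 will probably stay near the limit of compound 1 at > 30000 nM. The expected result is a number no higher from compound 1 to compound 4 (the limit leaves the size open). For compound 4 the estimated value is 30000 nM, with an expected range from 12000 nM to 60000 nM.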

Compound 4, half-maximal inhibitory concentration: 11800 nM
Beside the measured number, compound 4's estimate is 2.5-fold (0.41 log units) above it; the measured number lies below the stated range.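

Within the data shown here, this is the first measured change at the 4-fluorophenyl group, which all the earlier compounds held fixed. In this assay, methyl in place of fluoro at this position gives an at least 2.5-fold lower number from compound 1 to compound 4 (0.40 log units; beyond the scatter), so this part of the molecule can shift the result and not only the substituents changed earlier. Going by these compounds, the true size of the step stays unknown, since compound 1 gives only a limit and not a number, as does one other compound: the limit of > 30000 nM in this assay, at which 2 of the 4 values shown sit.

The compounds shown leave open whether methyl itself matters or simply the absence of fluoro, and a plain phenyl, a methoxy group or an ethyl chain here would help separate the two. On these data alone, it is also open whether the same swap would act alike on compound 2 or compound 3.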